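Propyl to hydrogen on the fused core: an inactive pair

The source may hold more compounds than are shown below. What is called first, only, known or untested is meant among the compounds shown, and "the series" means these compounds.

Compound 2 `CCCc1nc(C)c2cnnc(SC)n12` has been read in a functional assay for inhibition, with Homo sapiens as the target; a higher number here means a weaker inhibitor, a lower number a stronger inhibitor. In this assay compound 2 gives > 48000 nM, which is a limit of the assay and not a number. Compound 1 `CNc1nncc2c(C)ncn12` belongs to the same small set. In this assay compound 1 gives > 48000 nM, again a limit rather than a number. Compound 2 therefore stands nowhere on a scale of numbers: the two values shown both sit at the same limit, (the limit of > 48000 nM in this assay, at which 2 of the 2 values shown sit). Going by the values given here, compound 3 `CSc1nncc2c(C)ncn12` is the next member and has not yet been read in this assay. It differs from compound 2 in one place: hydrogen in place of propyl on an aromatic carbon, in words hydrogen in place of propyl on an aromatic carbon, the carbon between two ring nitrogen atoms of the five-membered aromatic ring of the fused system, two ring bonds from the ring atom that bears a methyl group. Among the compounds with values here, no step with numbers is available to set the size of this change. Compound 1 carries no propyl at that carbon and in this assay gives only > 48000 nM, a limit. The expected step from compound 2 to compound 3 is a step that the limit leaves unreadable from compound 2 to compound 3, none beyond the scatter. For compound 3 the estimate in this assay is 70000 nM, within 20000 nM to 300000 nM, most likely reported again only as a limit.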

Compound 3, half-maximal inhibitory concentration: > 48000 nM
Compound 3 gave a limit, no number; the forecaster's own chance of this, stated with the estimate: 85%; the middle value does not contradict the limit.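

No step can be read from compound 2 to compound 3 or from compound 1 to compound 3 in this assay, because every value is a limit and not a number: the limit of > 48000 nM in this assay, at which 3 of the 3 values shown sit.
The compounds shown leave open whether hydrogen in place of propyl, or methylsulfanyl in place of methylamino, changes inhibition at all.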